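The compounds below may be only part of what the source reports. "The series", "measured", "known", "first", "only" and "open" are said of these compounds alone.

Compound 1 `COc1cc(-c2nn(-c3cccc(NC(=O)c4ccc(Cl)c(C(F)(F)F)c4)c3)cc2-c2ccncc2)ccc1Cl` and compound 2 `COc1cc(-c2nn(-c3cccc(NC(=O)c4cccc(C(F)(F)F)c4)c3)cc2-c2ccncc2)ccc1Cl` share their core with compound 3 `O=C(Nc1cccc(-n2cc(-c3ccncc3)c(-c3ccc(Cl)c(O)c3)n2)c1)Nc1cc(C(F)(F)F)cc(C(F)(F)F)c1`. In a functional assay on SF-268 cells (Homo sapiens) for inhibition, read by sulforhodamine B assay, with a stated time of 48 h (a higher number here means a weaker inhibitor of growth, a lower number a stronger inhibitor of growth), compound 3 gives 2690 nM. Compound 1 gives only a limit in this assay, > 32500 nM. Compound 2 likewise gives only a limit, > 50000 nM. The step that the two limits leave unreadable from compound 1 to compound 2 therefore cannot be read, as both ends sit at limits (the limit of > 32500 nM in this assay, at which 1 of the 3 values shown sits; (the limit of > 50000 nM in this assay, at which 1 of the 3 values shown sits)). Compound 4 `COc1cc(-c2nn(-c3cccc(NC(=O)c4ccccc4)c3)cc2-c2ccncc2)ccc1Cl` differs from compound 2 by hydrogen in place of trifluoromethyl on an aromatic carbon. Among the measured compounds shown here, no measured step bears on this change; the only neighbouring step is unreadable. For the measured compounds named here, compound 4 is therefore expected to remain at or near the limit, with a step that the limit leaves unreadable from compound 2 to compound 4 expected to be no step readable beyond the scatter. The expected value for compound 4 in this assay is 60000 nM, within 20000 nM to 200000 nM.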

Compound 4, concentration for total growth inhibition: > 100000 nM
Compound 4: no number, only a limit; the forecaster's own chance of this, stated with the estimate: 85%; at least 1.6-fold (0.22 log units) between middle value and limit.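

Compound 4 gives only a limit, > 100000 nM, so its steps from compound 1 and compound 2 cannot be read. The compounds shown leave open whether hydrogen in place of trifluoromethyl changes growth inhibition in this assay at all.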